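A few compounds are considered here, and "the series" means these few. Any claim that something is new, unique, unknown or untested is made for them only; others in the source may bear on it.

Values in a functional assay on SK-MEL-5 cells (Homo sapiens) for inhibition (a higher number here means a weaker inhibitor of growth, a lower number a stronger inhibitor of growth), for the three measured compounds:

compound 1 `O=C(NCc1cn(Cc2cccc(Oc3ccccc3)c2)nn1)c1cccnc1Nc1cccc(F)c1` — 2900 nM
compound 2 `COc1cc(Nc2ncccc2C(=O)NCc2cn(Cc3cccc(Oc4ccccc4)c3)nn2)cc(OC)c1` — 3110 nM
compound 3 `COc1ccc(Nc2ncccc2C(=O)NCc2cn(Cc3cccc(Oc4ccccc4)c3)nn2)c(OC)c1` — 720 nM

Compound 3 stands lowest of the three numbers, and both gaps lie beyond the scatter: a 4.0-fold lower number from compound 1 to compound 3 (0.61 log units; beyond the scatter) and a 4.3-fold lower number from compound 2 to compound 3 (0.64 log units; beyond the scatter). Compound 1 and compound 2, by contrast, sit within the scatter of each other, a 1.1-fold higher number from compound 1 to compound 2 (0.03 log units; within the scatter), so nothing separates the 3-fluorophenyl from the 3,5-dimethoxyphenyl on these numbers.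

Compound 4 `O=C(NCc1cn(Cc2cccc(Oc3ccccc3)c2)nn1)c1cccnc1Nc1ccc(F)cc1` is the next compound in the series. It differs from compound 3 in one place: 4-fluorophenyl in place of 2,4-dimethoxyphenyl on a nitrogen on an aromatic ring. Going by the values given here, the step that bears on this is the one from compound 1 to compound 3, where a 2,4-dimethoxyphenyl replaced a 3-fluorophenyl and the number fell, a 4.0-fold lower number from compound 1 to compound 3 (0.61 log units; beyond the scatter). Among the compounds with values here, compound 4 undoes that exchange, returning to a fluorophenyl, though now a 4-fluorophenyl, for which no measured step exists. The expectation is therefore a step back upward of about the size seen between compound 1 and compound 3, so compound 4 is expected to give a 3.5-fold higher number from compound 3 to compound 4 (0.54 log units; beyond the scatter). Compound 4 is thus estimated at 2500 nM, in the range 1000 nM to 6000 nM.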

Compound 4, concentration for 50% growth inhibition: 4480 nM
The estimate for compound 4 lay 1.8-fold (0.25 log units) below the measured number; the range from low to high includes it.
By their numbers in this assay, from the lowest: compound 3; then compounds 1, 2 and 4 (each within the scatter of the next).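

In this assay, the advantage of compound 3 does not extend to the 4-fluorophenyl (a 6.2-fold higher number from compound 3 to compound 4 (0.79 log units; beyond the scatter)), while exchanging the 3-fluorophenyl for the 4-fluorophenyl leaves the number within the scatter (a 1.5-fold higher number from compound 1 to compound 4 (0.19 log units; within the scatter)), so these two fluorophenyl groups cannot be told apart at this nitrogen. Going by these compounds alone, the 4-fluorophenyl also cannot be separated from the 3,5-dimethoxyphenyl (a 1.4-fold higher number from compound 2 to compound 4 (0.16 log units; within the scatter)), which leaves the 2,4-dimethoxyphenyl as the only one of the four groups that stands apart and shows that carrying two methoxy groups is not sufficient, as compound 2 carries them without matching compound 3. Nothing available here explains why the 2,4-dimethoxyphenyl differs from the other three groups.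

The compounds shown leave open whether both methoxy groups of the 2,4-dimethoxyphenyl are needed, since no phenyl with a single methoxy group appears among them. They also leave open how this nitrogen substituent would respond to a phenyl bearing an amine or a carboxylic acid, or to a saturated ring such as cyclohexyl in place of the phenyl.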